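Adding Chlorine to the Phenyl Ring of Compound 2

The compounds below may be only part of what the source reports. "The series", "measured", "known", "first", "only" and "open" are said of these compounds alone.

Compound 1, `COc1cc(/C=C/C(=O)c2cccc(-n3cc(-c4ccccc4)[nH]c3=O)c2)ccc1O`: 1610 nM
Compound 2, `O=C(/C=C/c1cccc(O)c1)c1cccc(-n2cc(-c3ccccc3)[nH]c2=O)c1`: 1830 nM

Among the measured compounds shown here, both compounds have been tested in a functional assay on KM12 cells (Homo sapiens) for inhibition (a higher number here means a weaker inhibitor of growth, a lower number a stronger inhibitor of growth), and share the same core, differing only in the ring at the end of the double-bonded chain. For the measured compounds named here, the one measured step, a 1.1-fold higher number from compound 1 to compound 2 (0.06 log units; within the scatter), lies within the scatter, so the two numbers cannot be told apart. Compound 2 holds the higher of the two numbers, but its nearest neighbour, compound 1, sits within the scatter, and no order between them can be claimed.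

Compound 3, `O=C(/C=C/c1cccc(O)c1)c1cccc(-n2cc(-c3ccc(Cl)cc3)[nH]c2=O)c1`, differs from compound 2 by chloro in place of hydrogen on an aromatic carbon of the six-membered carbon ring, para to a large group; cut one bond further out, this reads phenyl to 4-chlorophenyl. Going by the values given here, no measured step touches this ring: the only step in hand, from compound 1 to compound 2, changes the far end of the chain and stayed within the scatter. With nothing bearing on this position, the expected step is a 1.0-fold lower number from compound 2 to compound 3 (0.01 log units; within the scatter), that is, none beyond the scatter. Compound 3 is therefore estimated at 1800 nM, with a range from 700 nM to 4500 nM.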

Compound 3, concentration for 50% growth inhibition: 1340 nM
Compound 3: middle estimate off by 1.3-fold (0.13 log units), on the high side, and the stated range covers the measured number.
By their numbers in this assay, from the lowest: compounds 3, 1 and 2 (each within the scatter of the next).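

In this assay, chloro in place of hydrogen on the phenyl ring gives a 1.4-fold lower number from compound 2 to compound 3 (0.14 log units; within the scatter), so the two numbers cannot be told apart. Among the compounds shown here, until this point, the only measured step concerned the ring on the double-bonded chain, and nothing was known about the phenyl ring on the other side of the shared core; this result shows that this ring can carry a chlorine at this position with no change that stands clear of the scatter. No measurement shown here offers an explanation for this outcome, so the result describes only what happened to the number.

From the compounds shown here alone, a single atom at a single position is a narrow test, so it remains open whether a carboxylic acid, an amine or a longer chain in the same place would leave the number just as undisturbed, or would move it clearly in either direction. Going by these compounds, it is also open whether the same chloro would behave alike on the phenyl ring of compound 1, whose chain ring carries a methoxy group as well as a hydroxyl.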